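The source may report more compounds than this note shows. Statements on the series, on what has been measured and on what is new or still open speak of the compounds shown alone.

For the measured compounds named here, compound 1 `COc1cccc(CN2Cc3c(NC(=O)c4ccccc4)n[nH]c3C2(C)C)c1` gives 1120 nM in an assay on Sf21 cells for inhibition of high affinity nerve growth factor receptor (Homo sapiens), read by HTRF, with a stated time of 30 min, in the presence of a further agent that is not named here (on this read-out lower numbers stand for stronger inhibition and higher numbers for weaker inhibition), the lowest of the two numbers measured so far. Compound 2 `CC1(C)c2[nH]nc(NC(=O)c3ccccc3)c2CN1Cc1ccc(F)cc1F` gives 2320 nM in this assay. Going by the values given here, the single measured step, a 2.1-fold higher number from compound 1 to compound 2 (0.32 log units; beyond the scatter), swapped the same arm for a fluorinated ring. Compound 3 `CC1(C)c2[nH]nc(NC(=O)c3ccccc3)c2CN1Cc1cc(F)c(F)c(F)c1` differs from compound 1 by 3,4,5-trifluorophenyl in place of 3-methoxyphenyl on a saturated chain carbon bound to an amine nitrogen in a ring. Among the compounds with values here, only that one step bears on this change, so a weakening of similar or somewhat larger size is expected in this assay, an expected step of a 2.3-fold higher number from compound 1 to compound 3 (0.37 log units; beyond the scatter). Compound 3 is therefore estimated at 2600 nM, with a range from 1000 nM to 6500 nM.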

Compound 3, half-maximal inhibitory concentration: 6960 nM
The estimate for compound 3 lay 2.7-fold (0.43 log units) below the measured number, outside the stated range (above it).
By their numbers in this assay, from the lowest: compound 1; then compound 2; then compound 3.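

In this assay, this position separates fluorinated rings from one another, not only from 3-methoxyphenyl: the change to 3,4,5-trifluorophenyl gives a 6.2-fold higher number from compound 1 to compound 3 (0.79 log units; beyond the scatter). The two fluorinated arms also differ beyond the scatter, with a 3.0-fold higher number from compound 2 to compound 3 (0.48 log units; beyond the scatter). No measurement on hand accounts for this order. The compounds shown leave open how an unsubstituted phenyl or a pyridine ring would rank at this position. They also leave open whether a methoxy group added to the fluorinated rings would recover the number of compound 1.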